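Oxime ether replaces methoxyethyl on the aryl group of a CRF ligand

The source may hold more compounds than are shown below. What is called first, only, known or untested is meant among the compounds shown, and "the series" means these compounds.

Measured compounds:
Compound 1, `CCCC(C)n1c(CC)nc2c(-c3ccc(C(C)OC)cc3Cl)ccnc21`: 3.5 nM
Compound 2, `CCCC(C)n1c(CC)nc2c(-c3cc(F)c(F)cc3Cl)ccnc21`: 2.4 nM
Compound 3, `CCCC(C)n1c(CC)nc2c(-c3ccc(OC)cc3C(F)(F)F)ccnc21`: 0.74 nM

Of the compounds shown here, three sharing one core have been measured in an assay for binding affinity to Corticotropin releasing factor receptor (Rattus norvegicus); on this read-out higher numbers stand for weaker inhibition and lower numbers for stronger inhibition. Compound 1 gives the highest of the three numbers. Compound 2 lies within the scatter of compound 1, so the two cannot be ordered. Compound 3 lies beyond the scatter, with a clearly lower number than compound 1.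

Compound 4, `CCCC(C)n1c(CC)nc2c(-c3ccc(/C(C)=N\OC)cc3Cl)ccnc21`, has not yet been measured in this assay. It differs from compound 1 in one place: a group of 5 heavy atoms (3 carbon, 1 nitrogen, 1 oxygen; no ring) in place of a group of 4 heavy atoms (3 carbon, 1 oxygen; no ring), on an aromatic carbon. The remaining parts of the molecule, including the chloro group, are unchanged.

For the measured compounds named here, no step between measured compounds mirrors this change, so the expectation rests on compound 1 alone, whose value 3.5 nM serves as the anchor. Compound 4 is expected to stay near that anchor, with an estimated step of a 1.2-fold lower number from compound 1 to compound 4 (0.07 log units; within the scatter), not beyond the scatter in either direction. Compound 4 is thus estimated at 3 nM, in the range 1 nM to 10 nM.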

Compound 4, inhibition constant: 2.3 nM
Compound 4: the middle estimate sits 1.3-fold (0.12 log units) above what was measured; low and high end bracket the measured number.
By their numbers in this assay, from the lowest: compound 3; then compounds 4, 2 and 1 (each within the scatter of the next).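

In this assay, putting the oxime ether in place of the 1-methoxyethyl group, on the aromatic carbon meta to a chloro group, gives a 1.5-fold lower number from compound 1 to compound 4 (0.18 log units; within the scatter), so the two compounds cannot be ordered. For the compounds shown here, this position therefore accepts a group with one more heavy atom, a double bond outside aromatic rings and an added hydrogen-bond acceptor without a change beyond the scatter, a comparison that no earlier pair offered, as none of them differed in one place only. Nothing measured here bears on what lies behind this result.

Going by these compounds, it remains open whether a longer chain, an amine or a carboxylic acid on this carbon would stay in the same range. Equally open, on these data alone, is how the oxime ether would read out with a trifluoromethyl group in place of the chloro group.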